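The source may hold more compounds than are shown below. What is called first, only, known or untested is meant among the compounds shown, and "the series" means these compounds.

Compound 1 has the structure `Cn1cccc1-c1cc(-c2ccc(Br)cc2)[nH]c(=O)c1C#N`. Its growth-inhibiting power was measured in a functional assay on HOP-92 cells (Homo sapiens) for cytotoxicity, read by sulforhodamine B assay, with a stated time of 48 h; a lower number here means a stronger inhibitor of growth, a higher number a weaker inhibitor of growth. In this assay compound 1 gives > 100000 nM, which is a limit of the assay rather than a number. Compound 2, with the structure `COc1ccc(-c2cc(-c3cccs3)[nH]c(=O)c2C#N)cc1`, was measured in the same way, and in this assay compound 2 gives > 100000 nM, again a limit and not a number. So where compound 1 stands can only be described as sitting at the limit of > 100000 nM in this assay, at which 2 of the 2 values shown sit.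

Compound 3 has the structure `Cn1cccc1-c1cc(-c2ccc(Br)cc2)n(C(=S)Nc2ccc(F)cc2)c(=O)c1C#N`. It differs from compound 1 by a group of 10 heavy atoms (7 carbon, 1 nitrogen, 1 fluorine, 1 sulfur; one six-membered aromatic ring of carbon only) in place of a hydrogen atom, on an aromatic nitrogen. Among the measured compounds shown here, no step between two measured compounds is available here, so nothing shows how a change of this kind shifts the read-out. The expectation is therefore cautious: the step from compound 1 to compound 3 is expected to be an at least 1.4-fold lower number from compound 1 to compound 3 (0.15 log units; that floor lies within the scatter), a shift toward stronger inhibition that may or may not carry the value below the limit. On this basis compound 3 is estimated to give 70000 nM in this assay, within a range from 15000 nM to 200000 nM.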

Compound 3, concentration for 50% growth inhibition: > 100000 nM
Compound 3: only a limit was reported (the forecaster's own chance of this, stated with the estimate: 55%); middle value at least 1.4-fold (0.15 log units) from the limit.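

In this assay compound 3 gives > 100000 nM, which is a limit of the assay and not a number. Among the compounds shown here, compound 1 sits at a limit too, so no step between compound 1 and compound 3 can be read: the limit of > 100000 nM in this assay, at which 3 of the 3 values shown sit. The compounds shown leave open whether the group added on the aromatic nitrogen changes growth inhibition at all.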